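This account rests on a few compounds, and the source may have more. Where it says the series, first, only, none or still open, it means among the compounds named here.

Measured compounds:
Compound 1 `CN(C)c1ccc(O)c2ccccc12` gives 3700 nM in an assay on isolated protein for inhibition of histone acetyltransferase p300 (Homo sapiens), read by fluorescence, with a stated time of 5 min, in the presence of a further agent that is not named here; a lower number here means a stronger inhibitor, a higher number a weaker inhibitor.
Compound 2 `Nc1ccc(CO)c2ccccc12` gives "not determined" (no result reported) in this assay.

Among the compounds with values here, compound 1 holds the only number reported in this assay; compound 2 carries no result there, so compound 1 cannot be placed relative to anything else, and no step between measured compounds exists to calibrate the next change.

Compound 3 `CS(=O)(=O)Nc1ccc(O)c2ccccc12` differs from compound 1 by one change: methanesulfonamido in place of dimethylamino on an aromatic carbon. Within the data shown here, no measured pair shows what such an exchange does in this assay, so the expected size of the step rests on nothing more than the single value of compound 1. The change is expected to move the value little, if at all, beyond the usual scatter, with the direction uncertain, as a 1.1-fold lower number from compound 1 to compound 3 (0.02 log units; within the scatter).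

Compound 3 is therefore estimated at 3500 nM in this assay, within a wide range from 700 nM to 18000 nM.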

Compound 3, half-maximal inhibitory concentration: 3000 nM
The estimate for compound 3 lay 1.2-fold (0.07 log units) above the measured number; low and high end bracket the measured number.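

Within the data shown here, with a 1.2-fold lower number from compound 1 to compound 3 (0.09 log units; within the scatter) in this assay, this is the first measured step at this place, on an aromatic carbon para to a hydroxy group, and it gives the earlier single value a point of comparison. The exchange of methanesulfonamido for dimethylamino leaves the two compounds indistinguishable in this assay, even though the entering group has 5 heavy atoms and 1 hydrogen-bond donor, while the leaving group has 3 heavy atoms and 0 hydrogen-bond donors. No measurement shown here accounts for this result.

The compounds shown leave open whether a carboxylic acid, a primary amine or a longer chain at this place would also stay within the scatter. They also leave open what happens when the hydroxy group itself gives way to a methoxy group.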